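Acid to Ketone on the Side Chain of Compound 3

A few compounds are considered here, and "the series" means these few. Any claim that something is new, unique, unknown or untested is made for them only; others in the source may bear on it.

Three compounds of the series carry results in an assay on Cerebral cortex for binding affinity to adenosine receptor A1 (Cavia porcellus), read by radioligand binding; on this read-out higher numbers stand for weaker inhibition and lower numbers for stronger inhibition. Compound 1 `CCCn1c(=O)n(CCOC)c(=O)c2[nH]cnc21` gives 2500 nM in this assay. Compound 2 `CCCn1c(=O)n(CCCCC(C)=O)c(=O)c2[nH]cnc21` gives 23100 nM. Among the compounds with values here, the single step between measured compounds differing in one place is a 9.2-fold higher number from compound 1 to compound 2 (0.97 log units; beyond the scatter). For compound 3 `CCCn1c(=O)n(C)c(=O)c2c1ncn2CCC(=O)O` only a limit of the assay is reported, > 200000 nM. That limit is the limit of > 200000 nM in this assay, at which 1 of the 3 values shown sits, so compound 3 stands without a number of its own and cannot be ordered against compound 1 or compound 2.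

Compound 4 `CCCn1c(=O)n(C)c(=O)c2c1ncn2CCC(C)=O` differs from compound 3 in one place: methyl in place of hydroxy on a carbonyl carbon. Cut one bond further out, the change reads carboxy to acetyl, or 2-carboxyethyl to 2-acetylethyl. Within the data shown here, no measured step makes this exact change. Among the measured compounds shown here, the step of a 9.2-fold higher number from compound 1 to compound 2 (0.97 log units; beyond the scatter) is the only one in which a 2-acetylethyl group takes part, and it concerns another pair of compounds and another exchange, so it sets no direction here; it shows only that compound 2, bearing a 2-acetylethyl chain, returns a number in this assay. Because compound 3 sits at > 200000 nM no step size can be read from the data.

The expected movement is an at least 4.0-fold lower number from compound 3 to compound 4 (0.60 log units; beyond the scatter), a gain in binding. Compound 4 is estimated at 50000 nM, between 10000 nM and 250000 nM, with a real chance that only a limit is again reported.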

Compound 4, inhibition constant: 30000 nM
Compound 4: middle estimate off by 1.7-fold (0.22 log units), on the high side; low and high end bracket the measured number.
By their numbers in this assay, from the lowest: compound 1; then compounds 2 and 4 (each within the scatter of the next). At a limit, above all of these: compound 3.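

Notes on the side chain of compound 4. In this assay, methyl in place of hydroxy on a carbonyl carbon gives a readable movement at this position: an at least 6.6-fold lower number from compound 3 to compound 4 (0.82 log units; beyond the scatter). The size of this step is only a lower bound, because compound 3 is held at a limit of the assay and has no number of its own: the limit of > 200000 nM in this assay, at which 1 of the 4 values shown sits.

Within the data shown here, what the earlier compounds did not show is that this side chain can return a number once its carboxy group is exchanged for acetyl, with compound 4 at 30000 nM.

Going by these compounds, the true distance from compound 3 to compound 4 stays open, and the data do not separate the loss of the hydroxy from the entry of the methyl. Also open, on these data alone, is where a primary amide, with an amino group on this carbonyl carbon, would fall relative to compound 3 and compound 4, and whether a longer chain carrying the acetyl group would move the number further.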